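Aryl amide replacing propyl on a chromone ether scaffold

The source may hold more compounds than are shown below. What is called first, only, known or untested is meant among the compounds shown, and "the series" means these compounds.

Compound 3 `CCCC(=O)Nc1cccc(NC(=O)COc2ccc3c(=O)ccoc3c2)c1` gives 176 nM in an assay on isolated protein for inhibition of Rho-associated protein kinase 2 (Homo sapiens), read by scintillation counting, radiometric assay and 33P incorporation, with a stated time of 40 min, in the presence of a further agent that is not named here (a higher number here means a weaker inhibitor, a lower number a stronger inhibitor), the lowest of the three values recorded. Compound 2 `COc1ccc(OCC(=O)Nc2cccc(NC(=O)c3ccc(N(C)C)cc3)c2)cc1F` gives 652 nM and compound 1 `CN(C)c1ccc(C(=O)Nc2cccc(NC(=O)COc3ccc4c(c3)NC(=O)CC4)c2)cc1` gives 3140 nM. Among the measured compounds shown here, the only single-site step known, a 4.8-fold lower number from compound 1 to compound 2 (0.68 log units; beyond the scatter), concerns the group on the oxygen on a saturated carbon, not the carbonyl carbon altered here, so it bears only indirectly on the present change. Compound 4 `O=C(COc1ccc2c(=O)ccoc2c1)Nc1cccc(NC(=O)c2ccc(OC(F)(F)F)cc2)c1` differs from compound 3 by 4-(trifluoromethoxy)phenyl in place of propyl on a carbonyl carbon. Compounds 1 and 2 carry an aromatic amide at that carbonyl carbon but differ from compound 3 in two places, so their values cannot be split into single steps. For the measured compounds named here, with no direct precedent, the estimated step for compound 4 is a 1.2-fold lower number from compound 3 to compound 4 (0.07 log units; within the scatter), expected to lie close to the scatter. Compound 4 is therefore estimated at 150 nM, within 40 nM to 600 nM.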

Compound 4, half-maximal inhibitory concentration: 77 nM
Beside the measured number, compound 4's estimate is 1.9-fold (0.29 log units) above it; measured number inside the range.
By their numbers in this assay, from the lowest: compound 4; then compound 3; then compound 2; then compound 1.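

In this assay, among the compounds shown here, the step of a 2.3-fold lower number from compound 3 to compound 4 (0.36 log units; beyond the scatter) is the first single-place reading at this carbonyl carbon. It shows that 4-(trifluoromethoxy)phenyl can replace propyl there, on the core of compound 3, with a lower number rather than a loss. No evidence on hand accounts for this step.

Open, from the compounds shown here alone, is whether an unsubstituted phenyl, a pyridine or a longer alkyl chain on this carbonyl carbon would move the number the same way. Also open, going by these compounds, is whether 4-(trifluoromethoxy)phenyl would do so on the cores of compound 1 and compound 2.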